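Swapping the methylamino of compound 1 for azidomethyl

The source may report more compounds than this note shows. Statements on the series, on what has been measured and on what is new or still open speak of the compounds shown alone.

Measured compounds:
compound 1 `CNc1cccc2c1nc(-c1c(F)cccc1F)n2Cc1c(F)cccc1F` — in a toxicity assay on CCRF-CEM cells (Homo sapiens) for cytotoxicity (on this read-out higher numbers stand for lower toxicity in this test and lower numbers for higher toxicity in this test), compound 1 gives 27.2 uM
compound 2 `CN(C)c1cccc2c1nc(-c1c(F)cccc1F)n2Cc1c(F)cccc1F` — in this assay compound 2 reaches only a limit, > 100 uM
compound 3 `Fc1cccc(F)c1Cn1c(-c2c(F)cccc2F)nc2c(CCl)cccc21` — in this assay compound 3 gives 13.4 uM

Among the two numbers, compound 1 holds the highest; its nearest neighbour is compound 3, with a 2.0-fold lower number from compound 1 to compound 3 (0.31 log units; beyond the scatter). Compound 2 is not a number but a limit of the assay (the limit of > 100 uM in this assay, at which 1 of the 3 values shown sits). The step to it is an at least 3.6-fold higher number from compound 1 to compound 2 (0.56 log units; beyond the scatter), and from compound 2 onward to compound 3 the step is an at least 7.4-fold lower number from compound 2 to compound 3 (0.87 log units; beyond the scatter).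

Compound 4 `[N-]=[N+]=NCc1cccc2c1nc(-c1c(F)cccc1F)n2Cc1c(F)cccc1F` is not yet measured. It differs from compound 1 in one place: azidomethyl in place of methylamino on an aromatic carbon. Among the measured compounds shown here, of the measured steps, the one from compound 1 to compound 3 bears most on this change, since there too methylamino gave way to a one-carbon group carrying a heavier substituent, and the number fell modestly; the step toward compound 2 runs the other way but keeps a nitrogen on the ring carbon. Compound 4 is therefore expected to give a modestly lower number, a 1.8-fold lower number from compound 1 to compound 4 (0.26 log units; within the scatter). The estimate for compound 4 is 15 uM, within 6 uM to 45 uM.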

Compound 4, half-maximal toxic concentration: > 100 uM
Compound 4: no number, only a limit; the forecaster's own chance of this, stated with the estimate: 5%; middle value at least 6.6-fold (0.82 log units) from the limit.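

In this assay, a one-carbon group on this aromatic carbon does not by itself bring the number down: azidomethyl in place of methylamino gives an at least 3.6-fold higher number from compound 1 to compound 4 (0.56 log units; beyond the scatter), the opposite direction to chloromethyl in compound 3. What the saturated chain carbon carries therefore sets the direction here, with azido in place of chloro giving an at least 7.4-fold higher number from compound 3 to compound 4 (0.87 log units; beyond the scatter). The step from compound 2 to compound 4 cannot be read, because each of the two compounds gives a limit and not a number: the limit of > 100 uM in this assay, at which 2 of the 4 values shown sit.

The compounds shown leave open whether this holds only for azido or also for other atoms on that chain carbon, such as the amine of aminomethyl or the hydroxyl of hydroxymethyl. They also leave open how a longer chain, such as azidoethyl, would read at this position.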